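Replacing a Hydroxy Group: Expected Tail Flick Activity

This account rests on a few compounds, and the source may have more. Where it says the series, first, only, none or still open, it means among the compounds named here.

Compound 1 `O=C(CN(c1ncnc2c1ncn2C1CCCCO1)C1CC1)N[C@@H](CO)C(=O)OCc1ccccc1`: 27.8%
Compound 2 `C[C@@H](O)[C@H](NC(=O)CN(c1nc(Cl)nc2[nH]cnc12)C1CC1)C(=O)O`: 18.6%
Compound 3 `O=C(CN(c1nc(Cl)nc2[nH]cnc12)C1CC1)NCC(=O)OCc1ccccc1`: 18.7%

Of the compounds shown here, three have been tested in a functional assay on the whole organism (Tail, strain ICR) with Mus musculus as the target, in the tail flick test, with a stated time of 30 min, at a dose of 25 umol/kg by the oral route; on this read-out lower numbers stand for a weaker effect and higher numbers for a stronger effect at the one dose given. Compound 1 stands at the top of the three numbers with 27.8%, yet its gaps to compound 3 and to compound 2 both fall within the usual scatter, so no real ordering can be read from them. No pair of these compounds differs in only one place, so no single measured step exists. Compound 4 `O=C(CN(c1ncnc2c1ncn2C1CCCCO1)C1CC1)N[C@@H](CCC(=O)OCc1ccccc1)C(=O)OCc1ccccc1` has not yet been measured. It differs from compound 1 in one place: (benzyloxycarbonyl)methyl in place of hydroxy on a saturated chain carbon, two bonds along the chain from an amide-type nitrogen and a carbonyl carbon. Among the compounds with values here, with no measured step as a guide, the step of a number 2.8 percentage points lower from compound 1 to compound 4 (within the scatter) is expected to stay within the scatter, in no clear direction. For compound 4 the estimate is 25%, within 8% to 45%.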

Compound 4, a percentage reported as activity, at one dose (the size of the read-out at that dose, not a potency): 32.6%
Estimate against measurement, compound 4: 7.6 percentage points below; low and high end bracket the measured number.
By their numbers in this assay, from the lowest: compounds 2, 3, 1 and 4 (each within the scatter of the next, the first and the last beyond it).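

In this assay, putting (benzyloxycarbonyl)methyl in place of hydroxy gives a number 4.8 percentage points higher from compound 1 to compound 4 (within the scatter), so the effect stays within the scatter. This position on the saturated chain carbon therefore accepts a much larger group, with an added aromatic ring and no hydrogen-bond donor, without a clear gain or loss at this dose. Nothing measured here explains this outcome. Still open, as far as these compounds go, is whether an amine or a simple fluorine at this position would move the read-out beyond the scatter. A single dose and time also leave open whether compound 4 and compound 1 would stay this close under other conditions.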